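This account rests on a few compounds, and the source may have more. Where it says the series, first, only, none or still open, it means among the compounds named here.

Measured so far:
compound 1 `CC1=C(C(=O)OCC(C)C)C(c2ccoc2)NC(=O)N1`: 16%
compound 2 `COC(=O)C1=C(C)N(C)C(=O)NC1c1ccoc1`: 7%

In an assay on membranes from HeLa cells for displacement of a labelled ligand from adenosine receptor A3 (Homo sapiens), read by scintillation counting, with a stated time of 180 min, tested at 1 uM (on this read-out lower numbers stand for less inhibition and higher numbers for more inhibition at the one concentration tested (going by the name of the read-out)), compound 2 gives 7%, and compound 1 gives 16%; the two values lie within the scatter of each other, so nothing separates them. Compound 3 `CC1=C(C(=O)OCC(C)C)C(c2ccoc2)NC(=O)N1C` is not yet measured. It differs from compound 2 in one place: isopropyl in place of hydrogen on a saturated chain carbon bound to an oxygen next to a carbonyl group. Among the measured compounds shown here, no measured pair shows this change alone. Compound 1 carries the same isobutoxycarbonyl group and gives 16%, so no step beyond the scatter is expected. Compound 3 is expected to give 12% in this assay, within 2% to 25%, an expected step of a number 5 percentage points higher from compound 2 to compound 3 (within the scatter).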

Compound 3, a percentage reported as inhibition, at one concentration (the size of the read-out at that concentration, not a potency): 16%
The estimate for compound 3 lay 4 percentage points below the measured number; the range from low to high includes it.
By their numbers in this assay, from the lowest: compounds 2, 1 and 3 (each within the scatter of the next).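

Among the compounds shown here, with compound 3 in hand, this assay reads two single changes for the first time, and methyl in place of hydrogen on an amide-type nitrogen in a ring gives no change at the digits printed from compound 1 to compound 3 (within the scatter). Isopropyl in place of hydrogen on a saturated chain carbon bound to an oxygen next to a carbonyl group gives a number 9 percentage points higher from compound 2 to compound 3 (within the scatter), so neither change separates its pair. No supporting data bear on these results. From the compounds shown here alone, whether a longer chain on that nitrogen, or a carboxylic acid in place of the methoxycarbonyl, would give a step beyond the scatter stays open.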